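This account rests on a few compounds, and the source may have more. Where it says the series, first, only, none or still open, it means among the compounds named here.

Of the compounds shown here, two with the same core have been measured in an ADME assay on HepG2 cells (Homo sapiens) for cytotoxicity, read by XTT assay, with a stated time of 48 h; on this read-out higher numbers stand for lower toxicity in this test and lower numbers for higher toxicity in this test. In that test compound 2 (`CCCCCCCCC[C@@H]1CC(O)=C(C(C)=O)C(=O)O1`) gives 71 ug/mL, the higher of the two numbers, while compound 1 (`CCCCCCCCC[C@@H]1CC(O)=C(C(=O)CCC)C(=O)O1`) gives 33 ug/mL. Compound 2 is therefore the less toxic of the pair on this read-out. The unmeasured compound 3 (`CCCCCCCCC[C@@H]1CC(O)=C(C(=O)CCCC)C(=O)O1`) differs from compound 2 by propyl in place of hydrogen on a saturated chain carbon bound to a carbonyl carbon, which is propyl in place of hydrogen on a saturated chain carbon bound to a carbonyl carbon. Among the measured compounds shown here, only one measured step bears on this change: a 2.2-fold higher number from compound 1 to compound 2 (0.33 log units; beyond the scatter). It is modest but beyond the scatter, and it falls at the same place, with hydrogen in place of ethyl. Compound 3 moves the opposite way, gaining a chain rather than losing one, so a modest fall in the number is expected in this assay. With a single step to go on, the data do not show whether propyl behaves as ethyl does. The expected change is a 2.8-fold lower number from compound 2 to compound 3 (0.45 log units; beyond the scatter). The estimate for compound 3 is 25 ug/mL, within an expected range of 11 ug/mL to 50 ug/mL.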

Compound 3, half-maximal cytotoxic concentration: 36 ug/mL
For compound 3 the middle estimate is 1.4-fold (0.16 log units) below the measured one, and the stated range covers the measured number.
By their numbers in this assay, from the lowest: compounds 1, 3 and 2 (each within the scatter of the next, the first and the last beyond it).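

Putting propyl in place of hydrogen on a saturated chain carbon bound to a carbonyl carbon gives a 2.0-fold lower number from compound 2 to compound 3 (0.29 log units; within the scatter) in this assay, whereas the smaller change at the same place had given a 2.2-fold higher number from compound 1 to compound 2 (0.33 log units; beyond the scatter), so the link between chain size and toxicity suggested by the first pair does not carry through clearly to the larger group. Adding methyl on a saturated chain carbon, three bonds along the chain from a carbonyl carbon, gives a 1.1-fold higher number from compound 1 to compound 3 (0.04 log units; within the scatter), which means that compound 1 and compound 3 cannot be told apart in this test, and that only the step from compound 1 to compound 2 stands clear of the scatter. No measurement available here accounts for these numbers.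

The compounds shown carry only unbranched saturated chains at this place, so it remains open how a branched group such as isopropyl, a phenyl ring or a terminal amine would read in this assay. Going by these compounds, it is also open whether a longer chain such as hexyl would stay level with compound 3 or move clear of the scatter.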